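A few compounds are considered here, and "the series" means these few. Any claim that something is new, unique, unknown or untested is made for them only; others in the source may bear on it.

Working notes on the series.

Two compounds have numbers in an assay on HepG2 cells for agonist activity at nuclear receptor subfamily 1 group I member 3 (Homo sapiens), read by a luciferase reporter, with a stated time of 23 h (on this read-out lower numbers stand for an effect already at smaller amounts and higher numbers for an effect only at larger amounts of compound), so far. Compound 1 `Clc1ccc(-c2nc3occn3c2/C=N/OCc2ccc(Cl)c(Cl)c2)cc1` gives 410 nM in this assay. Compound 2 `Clc1ccc(CO/N=C/c2c(-c3ccc(Br)cc3)nc3sccn23)cc1Cl` gives 480 nM in this assay. Compound 2 carries the higher of the two numbers, but the gap to compound 1 lies within the scatter of repeated measurements, so the two values cannot be told apart on this evidence. Within the data shown here, no pair of measured compounds differs in a single place, so no step is available to anchor the next change.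

Compound 3 `Clc1ccc(CO/N=C/c2c(-c3ccc(-c4ccccc4)cc3)nc3sccn23)cc1Cl` has not yet been measured in this assay. It differs from compound 2 as follows: phenyl in place of bromo on an aromatic carbon. There is no measured step of this kind in the series to set a size or direction, and the starting number of compound 2 480 nM is the only fixed point.

On that basis compound 3 is expected to give about 800 nM in this assay, within a range of 250 nM to 3000 nM. The step this estimate means, a 1.7-fold higher number from compound 2 to compound 3 (0.22 log units; within the scatter), is expected to be a modest move toward larger amounts, with a real chance that it stays within the scatter.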

Compound 3, half-maximal effective concentration: "not active" (no number reported)
For compound 3 the study gives words and no number, so the estimate cannot be set against anything.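

In this assay, among these compounds, compound 3 is reported in words as "not active", without a number, so no step from compound 2 to compound 3 can be read. No available evidence bears on this result. The compounds shown leave open whether any group other than bromo at this place gives a measurable value.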